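Working notes: (aminomethyl)carbonyl in place of methyl

The source may report more compounds than this note shows. Statements on the series, on what has been measured and on what is new or still open speak of the compounds shown alone.

Of the compounds shown here, two have measured values so far, both on the shared core. In a functional assay on HCT-116 cells (Homo sapiens) for antiproliferative activity (a higher number here means a weaker inhibitor, a lower number a stronger inhibitor), compound 1 `Cc1c2c(n3c1CCNC[C@@H](C)[C@H](C)Nc1cc-3ccc1C(N)=O)CC(C)(C)CC2=O` gives 24 nM and compound 2 `Cc1c2c(n3c1CCCN(C)[C@@H](C)[C@H](C)Nc1cc-3ccc1C(N)=O)CC(C)(C)CC2=O` gives 51 nM as the higher of the two numbers, a gap beyond the scatter. These two compounds differ in more than one place, so that gap isolates no single change.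

Next comes compound 3 `Cc1c2c(n3c1CCCN(C(=O)CN)[C@@H](C)[C@H](C)Nc1cc-3ccc1C(N)=O)CC(C)(C)CC2=O`, which has (aminomethyl)carbonyl in place of methyl on an amine nitrogen in a ring and otherwise matches compound 2. Among the measured compounds shown here, no measured pair covers a change on this nitrogen, so the data offer no direct guide. The expectation therefore starts from compound 2 at 51 nM and stays cautious. A modest weakening in this assay just beyond the scatter is expected, with the estimated step of a 2.2-fold higher number from compound 2 to compound 3 (0.33 log units; beyond the scatter) carrying wide uncertainty. For compound 3 the estimated value is 110 nM within an expected range from 30 nM to 400 nM in this read-out.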

Compound 3, half-maximal inhibitory concentration: 147 nM
Estimate against measurement, compound 3: 1.3-fold (0.13 log units) below; the range from low to high includes it.
By their numbers in this assay, from the lowest: compound 1; then compound 2; then compound 3.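

Among the compounds shown here, replacing methyl with (aminomethyl)carbonyl on the amine nitrogen in a ring gives, in this assay, a 2.9-fold higher number from compound 2 to compound 3 (0.46 log units; beyond the scatter), and this is the first step that can be tied to a single place. The step is modest, and compound 3 still gives 147 nM, so a substituent of 4 heavy atoms with a carbonyl and an amine on this nitrogen weakens the read-out without removing activity. Nothing measured alongside this step accounts for it, so the size of the change stands without an explanation.

From the compounds shown here alone, whether the weakening follows the carbonyl or the amine of the aminomethyl part stays open: an acetyl group on the same nitrogen would separate the two, and a hydrogen there would show what the methyl of compound 2 contributes. A longer chain ending in an amine, or a carboxylic acid in place of that amine, would show whether the step depends on the length of the substituent or on the group at its end.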